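Swapping the Aryl Group on a Thiosemicarbazone Nitrogen

This account rests on a few compounds, and the source may have more. Where it says the series, first, only, none or still open, it means among the compounds named here.

Of the compounds shown here, three have been measured in a functional assay on SGC-7901 cells (Homo sapiens) for antiproliferative activity, read by sulforhodamine B assay, with a stated time of 72 h; a lower number here means a stronger inhibitor, a higher number a weaker inhibitor. Compound 1 `COc1ccccc1NC(=S)N/N=C/c1ccc2ccccc2n1` gives > 100000 nM in this assay, which is a limit of the assay rather than a number. Compound 2 `NC(=S)N/N=C/c1cc2ccccc2s1` likewise gives > 100000 nM, again only a limit. Compound 3 `CN(C)C(=S)N/N=C/c1cnc2ccccc2n1`, on the other hand, gives a measured value of 170 nM in this assay. Compound 1 thus stands at the weak end of what has been seen so far, at the limit of > 100000 nM in this assay, at which 2 of the 3 values shown sit.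

Compound 4 `S=C(N/N=C/c1ccc2ccccc2n1)Nc1ccc(Cl)cc1` differs from compound 1 in a single place: 4-chlorophenyl in place of 2-methoxyphenyl on an amide-type nitrogen. For the measured compounds named here, no two of the measured compounds differ from each other in just one place, so there is no measured step of a comparable kind to lean on. Going by the values given here, the only real number in hand, that of compound 3, comes from a compound altered in several places at once, so it says little about this one exchange. Since compound 1 reports a limit, any number for compound 4 can only lie on the stronger side of it; the change is expected to amount to an at least 3.3-fold lower number from compound 1 to compound 4 (0.52 log units; beyond the scatter), with no certainty that it clears the scatter. Compound 4 is therefore estimated at 30000 nM, within a range from 3000 nM to 100000 nM, and with a fair chance that it too returns only a limit.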

Compound 4, half-maximal inhibitory concentration: 87600 nM
For compound 4 the middle estimate is 2.9-fold (0.47 log units) below the measured one; low and high end bracket the measured number.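

In this assay compound 1 gives > 100000 nM, which is a limit of the assay and not a number. For the compounds shown here, compound 4, carrying 4-chlorophenyl in place of 2-methoxyphenyl on the amide-type nitrogen, gives 87600 nM, the first true reading for a compound with an aryl group at this position. So an aryl group here need not push the result past the limit. The exchange amounts to an at least 1.1-fold lower number from compound 1 to compound 4 (0.05 log units; that floor lies within the scatter), and this floor alone does not establish a real gain, because the true size of the change stays hidden behind a reading that is only a limit: the limit of > 100000 nM in this assay, at which 2 of the 4 values shown sit.

What the compounds shown leave open is whether the weak result belongs to aryl groups on this nitrogen in general or only to these two. An ethyl chain or a cyclohexyl ring at the same place, on the same core, would test this, and a clearly lower number with either would show that this nitrogen can tolerate a change that matters far more than the one seen here.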